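Working notes: amide cap variation in a kinase inhibitor series

The source may hold more compounds than are shown below. What is called first, only, known or untested is meant among the compounds shown, and "the series" means these compounds.

Compound 1 `CN(C)c1ccc(C(=O)Nc2cccc(NC(=O)COc3ccc4c(c3)NC(=O)CC4)c2)cc1` gives in an assay on isolated protein for inhibition of Rho-associated protein kinase 1 (Homo sapiens), read by scintillation counting, radiometric assay and 33P incorporation, with a stated time of 40 min, in the presence of a further agent that is not named here (on this read-out lower numbers stand for stronger inhibition and higher numbers for weaker inhibition), a limit of > 10000 nM.
Compound 2 `Cc1c(OCC(=O)Nc2cccc(NC(=O)c3ccc(N(C)C)cc3)c2)ccc2c(=O)ccoc12` in this assay gives a limit of > 10000 nM.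
Compound 3 `CC(=O)Nc1cccc(NC(=O)COc2ccc3c(=O)ccoc3c2)c1` in this assay gives 2500 nM.

Going by the values given here, compound 3 holds the only number in the set; the other two entries are limits of the assay rather than numbers. Among the compounds with values here, two of the three results sit at the limit of > 10000 nM in this assay, at which 2 of the 3 values shown sit, so the measured spread is narrow, and no pair of measured compounds differs in a single place, leaving no measured step to lean on.

Compound 4 `N#Cc1ccc(C(=O)Nc2cccc(NC(=O)COc3ccc4c(=O)ccoc4c3)c2)cc1` differs from compound 3 in one place: 4-cyanophenyl in place of methyl on a carbonyl carbon. Within the data shown here, compounds 1 and 2 also carry a ring on that carbonyl carbon and both give only a limit, but they differ from compound 3 elsewhere too, so no direct step follows from them. The expected step from compound 3 to compound 4 is a 2.4-fold higher number from compound 3 to compound 4 (0.38 log units; beyond the scatter), a weakening in this assay somewhat beyond the scatter, with a fair chance that only a limit is returned. Compound 4 is estimated at 6000 nM, in the range 1500 nM to 20000 nM.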

Compound 4, half-maximal inhibitory concentration: 123 nM
Estimate against measurement, compound 4: 49-fold (1.69 log units) above; the measured number lies below the stated range.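

Going by these compounds alone, on the carbonyl carbon whose other neighbour is the amide-type nitrogen, exchanging methyl for 4-cyanophenyl gives a 20-fold lower number from compound 3 to compound 4 (1.31 log units; beyond the scatter) in this assay, the only measured single-place step. This position therefore accepts a ring carrying a nitrile, and the larger cap goes with stronger inhibition on the shared core. Compound 1 and compound 2 also carry a ring on that carbonyl carbon and return only limits, but each differs from compound 4 elsewhere as well, so those limits say nothing direct about this position.

As far as these compounds go, whether the gain belongs to the aromatic ring or to the nitrile stays open, as does the effect of a plain phenyl or a saturated cyclohexyl on the same carbonyl carbon. Nothing measured here accounts for the size of this step.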